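The compounds below may be only part of what the source reports. "The series", "measured", "known", "first", "only" and "open" are said of these compounds alone.

Measured compounds:
compound 1 `CCOC(=O)c1cnc(-c2ccccc2)nc1NN1C(=O)C=C(C)C1=O` — 100 nM
compound 2 `CCOC(=O)c1cnc(-c2ccccc2)nc1N(C)N1C(=O)C=C(C)C1=O` — 2000 nM

Going by the values given here, compound 2 gives the highest number of the two in a functional assay on Jurkat cells for inhibition of nuclear factor NF-kappa-B complex (Homo sapiens); on this read-out higher numbers stand for weaker inhibition and lower numbers for stronger inhibition; the only measured step is a 20-fold higher number from compound 1 to compound 2 (1.30 log units; beyond the scatter). Compound 3 `CCOC(=O)c1cnc(CC)nc1N(C)N1C(=O)C=C(C)C1=O` differs from compound 2 by ethyl in place of phenyl on an aromatic carbon. Among the compounds with values here, no measured step concerns this exchange, so nothing in the data points to a direction, and the one measured step speaks to another position. For compound 3 a step of a 2.0-fold higher number from compound 2 to compound 3 (0.30 log units; within the scatter) is expected, more likely upward than downward in this assay. The estimate for compound 3 is 4000 nM, with a range from 1000 nM to 20000 nM.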

Compound 3, half-maximal inhibitory concentration: 10000 nM
Compound 3: the middle estimate sits 2.5-fold (0.40 log units) below what was measured; the measured number falls inside the stated range.
By their numbers in this assay, from the lowest: compound 1; then compound 2; then compound 3.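

Ethyl in place of phenyl on the aromatic carbon between two ring nitrogen atoms gives a 5.0-fold higher number from compound 2 to compound 3 (0.70 log units; beyond the scatter) in this assay. This shows that this position, which the earlier step did not touch, also affects the read-out, and that here phenyl goes with stronger inhibition than ethyl. No available evidence bears on the reason for this difference.

Still open, going by these compounds, is how a propyl chain, a primary amine or a methoxy-substituted phenyl would behave at this position. Also open, on these data alone, is whether the same exchange would give a similar step on the core of compound 1.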